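A few compounds are considered here, and "the series" means these few. Any claim that something is new, unique, unknown or untested is made for them only; others in the source may bear on it.

Compounds measured so far:

Compound 1, `CCn1cc(C(=O)O)c(=O)c2cc(F)c(N3CCN(C(=N)NS(=O)(=O)c4ccc(C)cc4)CC3)cc21`: 32 nM
Compound 2, `Cc1ccc(S(=O)(=O)NC(=N)N2CCN(c3cc4c(cc3F)c(=O)c(C(=O)O)cn4C3CC3)CC2)cc1`: 32 nM
Compound 3, `CCn1cc(C(=O)O)c(=O)c2cc(F)c(N3CCN(C(=N)NS(=O)(=O)c4cccc(Cl)c4)CC3)cc21`: 32 nM

All three were tested in a functional assay on HeLa cells (Homo sapiens) for antiproliferative activity, read by MTT assay, with a stated time of 72 h; a lower number here means a stronger inhibitor, a higher number a weaker inhibitor. Compound 1 stands level with compound 2 and compound 3 at the digits shown. The change from compound 1 to compound 2, cyclopropyl in place of ethyl on an aromatic nitrogen, gave no change at the digits printed from compound 1 to compound 2 (within the scatter). The change from compound 1 to compound 3, 3-chlorophenyl in place of 4-methylphenyl on a sulfonyl sulfur, gave no change at the digits printed from compound 1 to compound 3 (within the scatter). Neither edit moved the readout beyond the usual scatter.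

The next compound, compound 4, is `CCn1cc(C(=O)O)c(=O)c2cc(F)c(N3CCN(C(=N)NS(=O)(=O)c4ccccc4)CC3)cc21`. It differs from compound 1 in a single place: hydrogen in place of methyl on an aromatic carbon. Read one bond further out, this is 4-methylphenyl going to phenyl on the sulfonyl sulfur.

Within the data shown here, of the two measured steps, the one from compound 1 to compound 3 bears most directly on this change, since it also rewrote the aryl group on the sulfonyl sulfur, and it produced no change at the digits printed from compound 1 to compound 3 (within the scatter). Removing the methyl entirely is a smaller edit than that one. On this basis the step from compound 1 to compound 4 is expected to be no change at the digits printed from compound 1 to compound 4 (within the scatter), no movement beyond the scatter in either direction. Compound 4 is therefore estimated at 32 nM, within a range of 16 nM to 64 nM.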

Compound 4, half-maximal inhibitory concentration: 32 nM
Compound 4: middle estimate and measured number agree at the digits printed; the measured number falls inside the stated range.
By their numbers in this assay, from the lowest: compounds 1, 2, 3 and 4 (each within the scatter of the next).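

Among these compounds, compound 4 carries no substituent at all on the aryl group on the sulfonyl sulfur, so it serves as the plain phenyl reference that the earlier compounds lacked. In this assay, removing the methyl gave no change at the digits printed from compound 1 to compound 4 (within the scatter) and removing the chloro gave no change at the digits printed from compound 3 to compound 4 (within the scatter), which means that neither 4-methylphenyl nor 3-chlorophenyl can be told apart from phenyl in this read-out. Among these compounds, then, a substituent on this ring is not needed to keep the value of compound 4 at 32 nM, although nothing shown here explains why this position tolerates these changes.

The compounds shown leave open whether any group on this ring can move the value beyond the scatter, for instance an amine or a carboxylic acid on the phenyl in place of the methyl, since only hydrogen, methyl and chloro appear there. From the compounds shown here alone, it also remains open whether the flat result holds for a larger change elsewhere, such as a longer chain in place of the ethyl on the aromatic nitrogen, or for a different group in place of the phenyl itself.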